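The source may report more compounds than this note shows. Statements on the series, on what has been measured and on what is new or still open speak of the compounds shown alone.

Of the compounds shown here, two sharing one core have been measured in a functional assay on HeLa cells (Homo sapiens) for cytotoxicity, read by neutral red uptake, with a stated time of 3 days; a higher number here means a weaker inhibitor, a lower number a stronger inhibitor. Compound 1 `[N-]=[N+]=Nc1c(F)c(N)c2c(=O)cc(-c3ccc(N)c(F)c3)oc2c1F` carries an azido group on an aromatic carbon of that core, and in this assay compound 1 gives 1200 nM. Compound 2 `COCc1c(F)c(N)c2c(=O)cc(-c3ccc(N)c(F)c3)oc2c1F` carries a methoxymethyl group in place of the azido group. In this assay compound 2 gives > 100000 nM, which is a limit of the assay and not a number, so compound 2 stands at the weak end of what was measured, with only a boundary known. For the measured compounds named here, the single measured step, an at least 83-fold higher number from compound 1 to compound 2 (1.92 log units; beyond the scatter), describes that exchange and reaches (the limit of > 100000 nM in this assay, at which 1 of the 2 values shown sits).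

Compound 3 `CN(C)CCCOCc1c(F)c(N)c2c(=O)cc(-c3ccc(N)c(F)c3)oc2c1F` differs from compound 2 by 2-(dimethylamino)ethyl in place of hydrogen on a saturated chain carbon bound to an oxygen on a saturated carbon; put another way, the methoxymethyl group becomes a (3-(dimethylamino)propoxy)methyl group. Going by the values given here, no measured step covers such a chain extension, and the step from compound 1 to compound 2 concerns a different exchange, so nothing measured points to either direction. Compound 2 stands at a limit, so even the starting point is uncertain. Compound 3 is expected to remain close to it, with an at least 1.2-fold lower number from compound 2 to compound 3 (0.09 log units; that floor lies within the scatter) as the expected step. In this assay compound 3 is therefore estimated at 80000 nM, within a range from 15000 nM to 300000 nM, and a limit rather than a number is again quite possible.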

Compound 3, half-maximal inhibitory concentration: 12000 nM
Compound 3: middle estimate off by 6.7-fold (0.82 log units), on the high side; the whole stated range lies above it.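

Extending the methoxymethyl group to a (3-(dimethylamino)propoxy)methyl group gives a measurable value in this assay, with an at least 8.3-fold lower number from compound 2 to compound 3 (0.92 log units; beyond the scatter), so a group at this aromatic carbon can retain activity without the azido group. The size of that step is only a floor, since the value of compound 2 is a limit and not a number: the limit of > 100000 nM in this assay, at which 1 of the 3 values shown sits. The longer group still does not match the azido group, with a 10-fold higher number from compound 1 to compound 3 (1.00 log units; beyond the scatter), so the azido group remains the better of the two at this aromatic carbon in this assay.

Compound 3 adds both chain length and a dimethylamino group in a single change, so the compounds shown cannot tell which of the two accounts for the step from the methoxymethyl group. A plain propoxymethyl chain with no amine, a shorter or longer chain ending in the same dimethylamino group, or a chain ending in a morpholine or a carboxylic acid would help to separate these two contributions.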